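A few compounds are considered here, and "the series" means these few. Any claim that something is new, unique, unknown or untested is made for them only; others in the source may bear on it.

Of the compounds shown here, two carrying the shared core have been measured in a functional assay on B16-F10 cells (Mus musculus) for antiproliferative activity, read by MTT assay, with a stated time of 48 h; a higher number here means a weaker inhibitor, a lower number a stronger inhibitor. Compound 1 `COc1ccc(-c2cn3cc(C4=CCN(S(=O)(=O)CCc5ccccc5)CC4)ccc3n2)cc1OC` gives 8080 nM in this assay. Compound 2 `COc1ccc(-c2cn3cc(C4=CCN(C(=O)C(C)(C)C)CC4)ccc3n2)cc1OC` gives 7100 nM in this assay, which is the lower of the two numbers, though the step of a 1.1-fold lower number from compound 1 to compound 2 (0.06 log units; within the scatter) lies within the scatter, so the two values cannot be told apart.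

The next compound, compound 3 `COc1ccc(-c2cn3cc(C4=CCN(S(=O)(=O)c5ccccc5)CC4)ccc3n2)cc1OC`, differs from compound 2 by one change: phenylsulfonyl in place of (tert-butyl)carbonyl on an amine nitrogen in a ring. For the measured compounds named here, the only measured step that bears on this is a 1.1-fold lower number from compound 1 to compound 2 (0.06 log units; within the scatter), which swapped a sulfonyl group for the (tert-butyl)carbonyl at the same nitrogen and produced no change beyond the scatter. Compound 3 returns a sulfonyl to that nitrogen, so no step beyond the scatter is expected in this assay, in either direction.

For compound 3 the estimate in this assay is therefore 8000 nM, with a range of 3500 nM to 18000 nM. This estimate corresponds to an expected step of a 1.1-fold higher number from compound 2 to compound 3 (0.05 log units; within the scatter), which is within the scatter.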

Compound 3, half-maximal inhibitory concentration: 13200 nM
Compound 3: the middle estimate sits 1.7-fold (0.22 log units) below what was measured; measured number inside the range.
By their numbers in this assay, from the lowest: compounds 2, 1 and 3 (each within the scatter of the next).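

In this assay, the step of a 1.9-fold higher number from compound 2 to compound 3 (0.27 log units; within the scatter) stays within the scatter, so a phenylsulfonyl group, with its six-membered aromatic ring, and the (tert-butyl)carbonyl group cannot be told apart at this amine nitrogen in a ring. For the compounds shown here, the step of a 1.6-fold higher number from compound 1 to compound 3 (0.21 log units; within the scatter) is also within the scatter, which adds a comparison the earlier compounds did not offer: with the sulfonyl kept in place, phenyl and phenethyl on the sulfonyl sulfur cannot be told apart either. No measurement is available that would explain these results or give them any cause.

The three groups shown at this nitrogen therefore give no step beyond the scatter, and they do not show whether any other group there would do so, such as a bare amine hydrogen, a small acetyl or a benzyl group. As far as these compounds go, it also remains open whether a phenylsulfonyl ring carrying a methoxy group, a fluorine atom or a carboxylic acid would separate from these values, or whether a longer chain on the sulfonyl sulfur would.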